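The compounds below may be only part of what the source reports. "The series", "measured", "known", "first", "only" and "open" are said of these compounds alone.

Measured in an in vitro ADME assay on microsomes from liver (Mus musculus) for pharmacokinetics, read by LC-MS; on this read-out lower numbers stand for slow clearance and higher numbers for fast clearance:
- Compound 1 `Cc1nc2cc(OC(F)(F)F)ccc2n1-c1ccc(C(=O)NC2CC2)s1`: 43 mL/min/kg
- Compound 2 `Cc1nc2cc(C(F)(F)F)ccc2n1-c1ccc(C(=O)NC2CC2)s1`: > 72 mL/min/kg

The reading for compound 2 is a limit of this assay and not a number. It stands at the limit of > 72 mL/min/kg in this assay, at which 1 of the 2 values shown sits, so its true position is not known. Among the compounds with values here, the one measured step, an at least 1.6-fold higher number from compound 1 to compound 2 (0.22 log units; that floor lies within the scatter), puts trifluoromethyl in place of trifluoromethoxy on an aromatic carbon and leaves the methyl untouched.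

Compound 3 `O=C(NC1CC1)c1ccc(-n2cnc3cc(C(F)(F)F)ccc32)s1` has not yet been measured in this assay. It carries hydrogen in place of methyl on an aromatic carbon, (hydrogen in place of methyl on an aromatic carbon). Within the data shown here, no measured step changes this methyl, so the data offer no size to carry over and no direction to favour. The expectation therefore rests on compound 2, whose > 72 mL/min/kg is a limit.

The expected change is an at least 1.1-fold lower number from compound 2 to compound 3 (0.06 log units; that floor lies within the scatter), and no shift beyond the scatter is anticipated. Compound 3 may well be reported only as a limit too. For compound 3 the estimated clearance is 62 mL/min/kg, with an expected range from 35 mL/min/kg to 110 mL/min/kg.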

Compound 3, clearance: > 72 mL/min/kg
Compound 3 gave a limit, no number; the forecaster's own chance of this, stated with the estimate: 40%; middle value at least 1.1-fold (0.06 log units) from the limit.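

Within the data shown here, compound 3, like compound 2, is reported in this assay only as a limit and not a number, so no step between the two can be read: the limit of > 72 mL/min/kg in this assay, at which 2 of the 3 values shown sit. The compounds shown leave open where the true clearance of compound 2 and compound 3 stands, and whether hydrogen in place of methyl on an aromatic carbon changes it at all.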